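Ethoxy on the Ethyl Chain of Compound 1: Compound 3

A few compounds are considered here, and "the series" means these few. Any claim that something is new, unique, unknown or untested is made for them only; others in the source may bear on it.

Compound 1, `CCc1cc(C)oc(=O)c1`, in a functional assay on A2780 cells (Homo sapiens) for inhibition; on this read-out lower numbers stand for stronger inhibition and higher numbers for weaker inhibition: > 50000 nM, a limit of the assay rather than a number.
Compound 2, `CCCCCC/C=C/c1cc(C)oc(=O)c1`, in this assay : > 50000 nM, again a limit, not a number.

Compound 1 therefore stands at the limit of > 50000 nM in this assay, at which 2 of the 2 values shown sit. Compound 3, `CCOCCc1cc(C)oc(=O)c1`, carries ethoxy in place of hydrogen on a saturated chain carbon, two bonds along the chain from an aromatic carbon. Among the compounds with values here, no step between two measured compounds is available to gauge such a change, so the step from compound 1 to compound 3 is expected to be a number no higher from compound 1 to compound 3 (the limit leaves the size open), that is, none beyond the usual scatter. Compound 3 is accordingly estimated at 50000 nM, within a range from 10000 nM to 200000 nM.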

Compound 3, half-maximal inhibitory concentration: > 50000 nM
Compound 3 gave a limit, no number; the forecaster's own chance of this, stated with the estimate: 85%; the middle value sits exactly at the limit.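

Within the data shown here, compound 1 and compound 3 each give a limit rather than a number, so no step between them can be read. The compounds shown leave open whether any change to the chain on the shared core would give a measurable number in this assay at all.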